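Aryl variation on the triazole nitrogen in the spiro series

The source may report more compounds than this note shows. Statements on the series, on what has been measured and on what is new or still open speak of the compounds shown alone.

Among the measured compounds shown here, compound 3 `N#CC1=C(N)Oc2c(N)cc3nc4ccccc4nc3c2C12C(=O)N(Cc1cnnn1-c1cccc(C(F)(F)F)c1)c1ccccc12` is the only member of this set that returns a number in a functional assay on HCT-116 cells (Homo sapiens) for antiproliferative activity, read by MTT assay, with a stated time of 48 h; a higher number here means a weaker inhibitor, a lower number a stronger inhibitor: compound 3 gives 18900 nM. Compound 1 `N#CC1=C(N)Oc2c(N)cc3nc4ccccc4nc3c2C12C(=O)N(Cc1cnnn1-c1ccc(F)cc1)c1ccccc12` returns only a limit of the assay in this assay, namely > 50000 nM. Compound 2 `N#CC1=C(N)Oc2c(N)cc3nc4ccccc4nc3c2C12C(=O)N(Cc1cnnn1-c1ccccc1Cl)c1ccccc12` likewise returns only a limit in this assay, namely > 50000 nM. Two of the three values therefore sit at the limit of > 50000 nM in this assay, at which 2 of the 3 values shown sit. The readable steps, an at least 2.6-fold lower number from compound 1 to compound 3 (0.42 log units; beyond the scatter) and an at least 2.6-fold lower number from compound 2 to compound 3 (0.42 log units; beyond the scatter), show that exchanging the aryl group on the aromatic nitrogen moves the read-out by at least a modest amount, while a step that the two limits leave unreadable from compound 1 to compound 2 cannot be sized because both ends are limits.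

Compound 4 `CCOc1ccc(-n2nncc2CN2C(=O)C3(C(C#N)=C(N)Oc4c(N)cc5nc6ccccc6nc5c43)c3ccccc32)cc1` differs from compound 3 by 4-ethoxyphenyl in place of 3-(trifluoromethyl)phenyl on an aromatic nitrogen. For the measured compounds named here, no measured step covers an ethoxy group or any oxygen-bearing aryl, so the direction of this change rests only on the two readable steps, which both favour the 3-(trifluoromethyl)phenyl member over a 4-fluorophenyl or 2-chlorophenyl analogue; the 4-ethoxyphenyl group resembles the 4-fluorophenyl of compound 1 in bearing its substituent at the same ring position. Compound 4 is therefore expected to be weaker than compound 3, with an estimated step of a 1.9-fold higher number from compound 3 to compound 4 (0.27 log units; within the scatter). The expected value for compound 4 in this assay is 35000 nM, within a range of 12000 nM to 100000 nM, with a fair chance that only a limit is returned.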

Compound 4, half-maximal inhibitory concentration: > 50000 nM
Compound 4 ended at the assay's limit; the forecaster's own chance of this, stated with the estimate: 45%; middle value at least 1.4-fold (0.15 log units) away from the limit.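

In this assay, among the compounds shown here, replacing 3-(trifluoromethyl)phenyl with 4-ethoxyphenyl on the aromatic nitrogen gives an at least 2.6-fold higher number from compound 3 to compound 4 (0.42 log units; beyond the scatter), a step beyond the scatter that extends the readable loss to an oxygen-bearing aryl group, which the earlier compounds did not cover. On these data alone, compound 3 thus remains the only aryl variant here to return a number, now against three different aryl groups rather than two, although the size of that advantage stays open-ended as compound 4 returns only a limit. The steps from compound 1 and compound 2 to compound 4 cannot be read, so 4-ethoxyphenyl, 4-fluorophenyl and 2-chlorophenyl cannot be ordered among themselves, and most of the set gives no graded read-out: the limit of > 50000 nM in this assay, at which 3 of the 4 values shown sit.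

The compounds shown leave open whether the number for compound 3 belongs to the trifluoromethyl group itself or to the ring position it occupies. They also leave open whether an amine or a carboxylic acid on the aryl ring, or an alkoxy chain longer than ethoxy, would bring a value inside the range of the assay.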